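Replacing Phenyl with a Halogenated Phenyl on the Aniline Nitrogen

The source may hold more compounds than are shown below. What is called first, only, known or untested is meant among the compounds shown, and "the series" means these compounds.

Compound 1 `COc1cc(N(CC2CC2)c2ccccc2)cnc1C(=O)[C@H]1C[C@@H]1C(=O)O` is the weaker of the two compounds measured in an assay on isolated protein for inhibition of leukotriene C4 synthase (Homo sapiens), read by LC-MS, with stated times of 45 min and 20 min; on this read-out higher numbers stand for weaker inhibition and lower numbers for stronger inhibition. In this assay, among the measured compounds shown here, compound 1 gives 1640 nM, the highest of the two numbers known here. Compound 2 `COc1cc(N(CC(C)C)c2ccc(F)c3ccccc23)cnc1C(=O)[C@H]1C[C@@H]1C(=O)O` sits far below it: in this assay compound 2 gives 2.26 nM, a gap well beyond the usual scatter. Compound 2 differs from compound 1 in more than one place, so the gap cannot be assigned to a single change.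

Compound 3 `COc1cc(N(CC2CC2)c2cc(Cl)ccc2F)cnc1C(=O)[C@H]1C[C@@H]1C(=O)O` is not yet measured. It differs from compound 1 in one place only: 5-chloro-2-fluorophenyl in place of phenyl on a nitrogen on an aromatic ring. For the measured compounds named here, the larger, halogen-bearing aromatic ring of compound 2 goes with a much lower number, which suggests that adding halogens to the ring on this nitrogen may move compound 3 in the same direction, though compound 2 is the only point of comparison and it carries a different chain on the nitrogen too. The step from compound 1 to compound 3 is therefore expected to be a 14-fold lower number from compound 1 to compound 3 (1.14 log units; beyond the scatter), toward stronger inhibition. Compound 3 is estimated to give 120 nM in this assay, with a likely range from 20 nM to 700 nM, an estimate resting on compound 2 giving 2.26 nM.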

Compound 3, half-maximal inhibitory concentration: 34.3 nM
Beside the measured number, compound 3's estimate is 3.5-fold (0.54 log units) above it; measured number inside the range.
By their numbers in this assay, from the lowest: compound 2; then compound 3; then compound 1.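

Among the compounds shown here, this result gives the first clean reading of the ring on the aniline nitrogen. The chain on that nitrogen and the rest of the core stay the same. In this assay, 5-chloro-2-fluorophenyl in place of phenyl gives a 48-fold lower number from compound 1 to compound 3 (1.68 log units; beyond the scatter), so a change to this ring alone is enough to produce a large step toward stronger inhibition, something the gap between compound 1 and compound 2 could not show with more than one place changed. Nothing available here explains why this ring change has so large an effect.

As far as these compounds go, the chlorine and the fluorine enter together, so their separate shares of the step remain unknown, and a phenyl ring carrying only one of these halogens, or carrying a nitrile or a trifluoromethyl group instead, would be needed to separate them. From the compounds shown here alone, it also remains open whether 5-chloro-2-fluorophenyl would give a step of similar size with a different chain on the nitrogen, such as a longer alkyl chain.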